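Para Substituent Swap: Hydroxy to Nitro on the Phenoxy Ring

The source may report more compounds than this note shows. Statements on the series, on what has been measured and on what is new or still open speak of the compounds shown alone.

Compound 1 `C/N=C(/S)C1(c2cccnc2)CCCC/C1=C\COc1ccccc1`: 65 nM
Compound 2 `C/N=C(/S)C1(c2cccnc2)CCCC/C1=C\COc1ccc(O)cc1`: 300 nM

In a functional assay (aorta) with Rattus norvegicus as the target (a lower number here means a stronger inhibitor, a higher number a weaker inhibitor), compound 1 gives 65 nM, while compound 2 gives 300 nM, the higher of the two numbers shown; the step of a 4.6-fold higher number from compound 1 to compound 2 (0.66 log units; beyond the scatter) separates them. Compound 3 `C/N=C(/S)C1(c2cccnc2)CCCC/C1=C\COc1ccc([N+](=O)[O-])cc1` differs from compound 2 by nitro in place of hydroxy on an aromatic carbon. Within the data shown here, no measured step covers a nitro group, so the only guide is that the hydroxy step weakened compound 2 relative to compound 1. Compound 3 is therefore expected to land between the two measured values, an estimated 2.0-fold lower number from compound 2 to compound 3 (0.30 log units; within the scatter) to roughly 150 nM, with a range of 40 nM to 600 nM.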

Compound 3, concentration for 90% inhibition: 100 nM
Compound 3: the middle estimate sits 1.5-fold (0.18 log units) above what was measured; the range from low to high includes it.
By their numbers in this assay, from the lowest: compounds 1 and 3 (each within the scatter of the next); then compound 2.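

At this aromatic carbon in this assay, the step of a 3.0-fold lower number from compound 2 to compound 3 (0.48 log units; beyond the scatter) shows that the weakening seen with hydroxy does not extend to every group placed there. With nitro in place of hydrogen, the step of a 1.5-fold higher number from compound 1 to compound 3 (0.19 log units; within the scatter) shows that a group at this carbon need not shift the number beyond the scatter. Nothing available explains why hydroxy and nitro differ here. Going by these compounds, whether an amine, a methoxy group or chlorine at this carbon would behave like nitro or like hydroxy stays open.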